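A few compounds are considered here, and "the series" means these few. Any claim that something is new, unique, unknown or untested is made for them only; others in the source may bear on it.

Measured in a functional assay on MDA-MB-231 cells (Homo sapiens) for cytotoxicity, read by MTT assay, with a stated time of 48 h; on this read-out lower numbers stand for stronger inhibition and higher numbers for weaker inhibition:
- compound 1 `Cc1ccc(NC(=O)NCCCCC(c2ccc(F)cc2)c2ccc(F)cc2)cc1`: > 20000 nM (a limit)
- compound 2 `O=C(NCCCCC(c1ccc(F)cc1)c1ccc(F)cc1)Nc1ccc(Cl)c([N+](=O)[O-])c1`: 4060 nM
- compound 3 `O=C(NCCCCC(c1ccc(F)cc1)c1ccc(F)cc1)Nc1ccc(Br)cc1I`: > 20000 nM (a limit)

Compound 3 stands at the limit of > 20000 nM in this assay, at which 2 of the 3 values shown sit. Compound 4 `O=C(NCCCCC(c1ccc(F)cc1)c1ccc(F)cc1)c1ccc(Cl)c(C(F)(F)F)c1` differs from it as follows: 4-chloro-3-(trifluoromethyl)phenyl in place of (4-bromo-2-iodophenyl)amino on a carbonyl carbon. In words, 4-chloro-3-(trifluoromethyl)phenyl enters in place of (4-bromo-2-iodophenyl)amino on a carbonyl carbon.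

Among the compounds with values here, two measured steps bear on this change: an at least 4.9-fold lower number from compound 1 to compound 2 (0.69 log units; beyond the scatter) and an at least 4.9-fold higher number from compound 2 to compound 3 (0.69 log units; beyond the scatter). Both swap the ring group on an amide-type nitrogen, so the ring group can shift the number clearly. The entering group's name resembles the 4-chloro-3-nitrophenyl of compound 2, which gives 4060 nM. Within the data shown here, no measured step removes that nitrogen, so this guide is only partial. A modest move to a lower number is therefore expected, namely an at least 2.8-fold lower number from compound 3 to compound 4 (0.45 log units; beyond the scatter). For compound 4 the estimated value is 7000 nM, with an expected range of 2500 nM to 20000 nM.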

Compound 4, half-maximal inhibitory concentration: 11700 nM
Compound 4: middle estimate off by 1.7-fold (0.22 log units), on the low side, and the stated range covers the measured number.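

Compound 4 sets its ring group directly on the carbonyl carbon, with no amino nitrogen between them, and it still gives a measured number rather than a limit. Against the ring group of compound 2, this change gives a 2.9-fold higher number from compound 2 to compound 4 (0.46 log units; beyond the scatter). The steps of an at least 1.7-fold lower number from compound 3 to compound 4 (0.23 log units; that floor lies within the scatter) and an at least 1.7-fold lower number from compound 1 to compound 4 (0.23 log units; that floor lies within the scatter) give only floors, because compound 1 and compound 3 each sit at a limit: the limit of > 20000 nM in this assay, at which 2 of the 4 values shown sit.

Still open, from the compounds shown here alone, is whether the step from compound 2 reflects losing the amino nitrogen or trifluoromethyl standing where nitro stood, as both changes arrive together. A (4-chloro-3-(trifluoromethyl)phenyl)amino group on the same carbonyl carbon would separate the two.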